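A methoxy removed from a dimethoxyphenyl amide

The compounds below may be only part of what the source reports. "The series", "measured", "known", "first", "only" and "open" are said of these compounds alone.

All four compounds share one core and differ only in the groups attached to it. Compound 1 `C=CC1=C(C(=O)NCc2ccc(C)cc2)C(c2ccc(F)cc2)OC1` carries a fluorine on its aryl ring and a methylbenzyl amide. In a functional assay on HeLa cells (Homo sapiens) for cytotoxicity, read by MTT assay, with a stated time of 24 h (on this read-out lower numbers stand for stronger inhibition and higher numbers for weaker inhibition), compound 1 reaches only the limit of the assay, > 100000 nM. Compound 2 `C=CC1=C(C(=O)NC2CCCCC2)C(c2ccc(OC)cc2)OC1` pairs a single methoxy on the aryl ring with a cyclohexyl amide, and in this assay compound 2 gives 24800 nM. Compound 3 `C=CC1=C(C(=O)NCc2ccc(C)cc2)C(c2ccc(OC)c(OC)c2)OC1` keeps the methylbenzyl amide of compound 1 but bears two methoxy groups on the aryl ring. In this assay compound 3 also sits at the limit, > 100000 nM, a sign of no measurable effect rather than a number; it shares this with the limit of > 100000 nM in this assay, at which 2 of the 3 values shown sit.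

Compound 4 `C=CC1=C(C(=O)NCc2ccc(C)cc2)C(c2ccc(OC)cc2)OC1` has not yet been measured. It differs from compound 3 by hydrogen in place of methoxy on an aromatic carbon, so that only one methoxy remains. Among the compounds with values here, no pair of measured compounds differs in exactly this way, and the weak values seen so far leave little room for a step to be resolved. Compound 4 is therefore expected to stay weak, with a step of an at least 1.2-fold lower number from compound 3 to compound 4 (0.09 log units; that floor lies within the scatter) that cannot be told from the scatter, and an estimate of 80000 nM spanning 20000 nM to 300000 nM.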

Compound 4, half-maximal inhibitory concentration: 15900 nM
Compound 4: middle estimate off by 5.0-fold (0.70 log units), on the high side, and the stated range ends above it.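

Taking one methoxy off the aromatic ring gives an at least 6.2-fold lower number from compound 3 to compound 4 (0.79 log units; beyond the scatter) in this assay, so the aryl ring can decide whether the methylbenzyl amide series shows a measurable effect at all. Placing methoxy instead of fluoro on the same ring gives an at least 6.2-fold lower number from compound 1 to compound 4 (0.79 log units; beyond the scatter) and points the same way: with this amide, the single methoxy is the only aryl pattern shown that gives a number. Changing the amide from cyclohexyl to 4-methylbenzyl gives a 1.6-fold lower number from compound 2 to compound 4 (0.19 log units; within the scatter) and so shows no resolved effect of the amide group between these two compounds.

From the compounds shown here alone, whether a hydroxy, a chlorine or an ethoxy group on this ring would do better remains open. Going by these compounds, the true size of the two larger steps also stays unknown, since each starts from a limit and gives only a floor: the limit of > 100000 nM in this assay, at which 2 of the 4 values shown sit.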